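Fluorophenyl to dichlorophenyl on a shared chromanone-type core

This account rests on a few compounds, and the source may have more. Where it says the series, first, only, none or still open, it means among the compounds named here.

Measured compounds:
compound 1 `CC(C)=CCOc1ccc2c(c1)OC(c1ccccc1F)CC2=O` gives 6360 nM in a functional assay; on this read-out lower numbers stand for stronger inhibition and higher numbers for weaker inhibition
compound 2 `CC(C)=CCOc1ccc2c(c1)OC(c1ccc(F)cc1)CC2=O` gives 7320 nM in this assay

Compound 2 stands at the higher of the two numbers, but its neighbour compound 1 differs by a 1.2-fold higher number from compound 1 to compound 2 (0.06 log units; within the scatter), so the two cannot be told apart.

Compound 3 `CC(C)=CCOc1ccc2c(c1)OC(c1ccc(Cl)cc1Cl)CC2=O` is not yet measured. It differs from compound 2 in one place: 2,4-dichlorophenyl in place of 4-fluorophenyl on a saturated ring carbon.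

Among the compounds with values here, only one measured step exists, from compound 1 to compound 2, and it swaps one fluorophenyl pattern for another without leaving the scatter. Within the data shown here, no step shows what chlorine, or a second halogen, does at this position, so there is no firm basis for a direction. Compound 3 is therefore expected to stay close to compound 2, with a step of a 1.3-fold lower number from compound 2 to compound 3 (0.12 log units; within the scatter), and its value in this assay is estimated at 5500 nM within a range of 1500 nM to 18000 nM.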

Compound 3, half-maximal inhibitory concentration: 5260 nM
Compound 3: the middle estimate sits 1.0-fold (0.02 log units) above what was measured, within the range that was stated.
By their numbers in this assay, from the lowest: compounds 3, 1 and 2 (each within the scatter of the next).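

Within the data shown here, this is the first view of chlorine, and of two halogens rather than one, on the phenyl group at this saturated ring carbon next to the ring oxygen. In this assay, the change to 2,4-dichlorophenyl gives a 1.4-fold lower number from compound 2 to compound 3 (0.14 log units; within the scatter), and likewise a 1.2-fold lower number from compound 1 to compound 3 (0.08 log units; within the scatter), so all three halogen patterns remain indistinguishable on this read-out and none of them stands out. Nothing available explains why this position responds so little to the change.

As far as these compounds go, all three compounds carry only halogens on this phenyl group, so what an amine, a carboxylic acid or a methoxy group would do there remains open. The ether chain on the shared core is also the same in all three, leaving open what a hydroxyl group in its place would do.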